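A bromo for hydroxy swap on a core at the limit

The source may hold more compounds than are shown below. What is called first, only, known or untested is meant among the compounds shown, and "the series" means these compounds.

Compound 1, `O=C(/C=C\c1cccc(O)c1)N1N=C(c2ccncc2)OC1c1c[nH]c2ccccc12`, in an ADME assay on PANC-1 cells (Homo sapiens) for cytotoxicity, read by MTT assay, with a stated time of 48 h (on this read-out lower numbers stand for stronger inhibition of growth and higher numbers for weaker inhibition of growth), gives > 30 ug/mL, which is a limit of the assay and not a number.
Compound 2, `O=C(/C=C\c1ccc(O)cc1)N1N=C(c2ccncc2)OC1c1c[nH]c2ccccc12`, gives > 30 ug/mL, again a limit.
Compound 3, `O=C(/C=C\c1ccccc1F)N1N=C(c2ccncc2)OC1c1c[nH]c2ccccc12`, gives > 30 ug/mL, also a limit.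

Compound 1 therefore stands only at a limit in this assay; no number places it against the other two. Compound 4, `O=C(/C=C\c1cccc(Br)c1)N1N=C(c2ccncc2)OC1c1c[nH]c2ccccc12`, differs from it in one place: bromo in place of hydroxy on an aromatic carbon. The measured steps that touch the same ring are a step that the two limits leave unreadable from compound 1 to compound 2, a step that the two limits leave unreadable from compound 1 to compound 3 and a step that the two limits leave unreadable from compound 2 to compound 3; none of them can be read in size, since (the limit of > 30 ug/mL in this assay, at which 3 of the 3 values shown sit). The change from hydroxy to bromo has no measured counterpart among these compounds. With every comparison compound sitting at the limit, the expected outcome for compound 4 is once more a limit rather than a number, with only a modest chance of a readable value. The step from compound 1 is estimated as a step that the limit leaves unreadable from compound 1 to compound 4. Compound 4 is expected to give 40 ug/mL in this assay, within a range from 12 ug/mL to 120 ug/mL.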

Compound 4, concentration for 50% growth inhibition: > 30 ug/mL
Compound 4 ended at the assay's limit; the forecaster's own chance of this, stated with the estimate: 70%; the middle value is on the limit's open side.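

Compound 4 joins compound 1, compound 2 and compound 3 at the same limit, so no step among them can be read in size, because none gives a number: the limit of > 30 ug/mL in this assay, at which 4 of the 4 values shown sit.

The compounds shown leave open how far any of these changes on the ring shifts growth inhibition in this assay.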